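Replacing the anilino phenyl of compound 1 with methyl

The compounds below may be only part of what the source reports. "The series", "measured", "known", "first", "only" and "open" are said of these compounds alone.

Among the compounds with values here, compound 1, `CC1CCC(=NNc2ccccc2)c2ncc(C(=O)O)c(=O)n21`, is the only compound of this series with a definite number in a functional assay on the whole organism with Rattus norvegicus as the target; on this read-out lower numbers stand for an effect already at smaller amounts and higher numbers for an effect only at larger amounts of compound: compound 1 gives 1.2 umol/kg. Compound 2, `CC1CCC(=NNc2ccccc2C(=O)O)c2ncc(C(=O)O)c(=O)n21`, carries a carboxy in place of hydrogen on an aromatic carbon and reaches only a limit of this assay, > 100 umol/kg. Compound 3, `CCc1nc2n(c(=O)c1C(=O)O)C(C)CCC2=NNc1ccccc1`, carries an ethyl in place of hydrogen on an aromatic carbon and likewise reaches only a limit, > 320 umol/kg. Both changes were costly: an at least 83-fold higher number from compound 1 to compound 2 (1.92 log units; beyond the scatter) and an at least 260-fold higher number from compound 1 to compound 3 (2.42 log units; beyond the scatter).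

Compound 4, `CNN=C1CCC(C)n2c1ncc(C(=O)O)c2=O`, differs from compound 1 by methyl in place of phenyl on an amine nitrogen. Neither measured step touches this place, so the two steps speak only indirectly; still, the change to the phenyl in compound 2 and the change to the core in compound 3 each moved the number far beyond the scatter, and removing the phenyl altogether is a larger alteration than either. A substantial rise is therefore expected for compound 4, a 25-fold higher number from compound 1 to compound 4 (1.40 log units; beyond the scatter), with a fair chance that only a limit is recorded. The estimate for compound 4 is 30 umol/kg, within 5 umol/kg to 200 umol/kg.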

Compound 4, dose for 50% inhibition: > 100 umol/kg
Compound 4 ended at the assay's limit; the forecaster's own chance of this, stated with the estimate: 40%; middle value at least 3.3-fold (0.52 log units) away from the limit.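

Compound 1 and compound 4 differ only by anilino to methylamino, and this change gives an at least 83-fold higher number from compound 1 to compound 4 (1.92 log units; beyond the scatter) in this assay. The earlier steps shown here altered the phenyl of compound 1 or the shared core while keeping the phenyl, whereas this one shows that the phenyl itself cannot be replaced by methyl on the amine nitrogen without a large loss on this read-out. Compound 4 stands only at a limit of the assay, so the step gives a lower bound and not a full size, and this limit is shared with compound 2: the limit of > 100 umol/kg in this assay, at which 2 of the 4 values shown sit.

The compounds shown leave open whether a ring is needed at this nitrogen at all, or whether a cyclohexyl, a benzyl or a longer chain such as butyl could take the place of phenyl. They also leave open how a small group such as fluoro or methoxy on the phenyl would read, since the only substituent shown there is the carboxy of compound 2.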